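Chloro substitution on two cores in a gastric inhibition read-out

The source may report more compounds than this note shows. Statements on the series, on what has been measured and on what is new or still open speak of the compounds shown alone.

Measured compounds:
compound 1 `N=C(S)CCn1nc(-c2ccc(Cl)c(Cl)c2)ccc1=O` gives 55.8%
compound 2 `N=C(S)CCn1nc(-c2ccc(Cl)cc2)ccc1=O` gives 42.5%
compound 3 `N=C(S)CCN1N=C(c2ccccc2)CCC1=O` gives 38.2%

All three compounds were tested in a functional assay on the whole organism (stomach) for inhibition, with Rattus norvegicus as the target, at a dose of 100 mg/kg by the intraduodenal route; on this read-out higher numbers stand for more inhibition at the one dose given (going by the name of the read-out) and lower numbers for less inhibition. Compound 1 carries the higher number of the set; the step of a number 13.3 percentage points higher from compound 2 to compound 1 (beyond the scatter) rests on the change (chloro in place of hydrogen on an aromatic carbon). Compound 3, whose core differs from that of compound 2, gives a number that lies within the scatter of compound 2 but beyond the scatter below compound 1; the difference between the two cores is not broken down here.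

Compound 4 `N=C(S)CCN1N=C(c2ccc(Cl)cc2)CCC1=O` has not yet been measured. Relative to compound 3 it carries the change (chloro in place of hydrogen on an aromatic carbon). This is the same kind of change as that from compound 2 to compound 1, though not the same: in compound 1 the entering chloro sits ortho to a chloro group and meta to a large group, whereas in compound 4 it sits para to a large group on a ring that carries no other chloro, and the core is different.

Among the compounds with values here, only one step of this kind is known, the one from compound 2 to compound 1, so the expectation for compound 4 rests on a single comparison made on a different core. A step of a number 9.8 percentage points higher from compound 3 to compound 4 (within the scatter) is expected, smaller than the step seen between compound 2 and compound 1 because that step a number 13.3 percentage points higher from compound 2 to compound 1 (beyond the scatter) came with a second chloro already present. Compound 4 is therefore estimated at 48% in this assay, within a band from 35% to 62%.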

Compound 4, a percentage reported as inhibition, in the whole organism at one dose (the size of the read-out at that dose, not a potency): 43.1%
The estimate for compound 4 lay 4.9 percentage points above the measured number, and the stated range covers the measured number.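

In this assay, chloro in place of hydrogen on an aromatic carbon gives a number 4.9 percentage points higher from compound 3 to compound 4 (within the scatter), so on the core of compound 3 this change does not separate the pair beyond the usual scatter. Set beside the step on the other core, the size of the change does not differ beyond what repeated measurements allow: the same change on two cores in this assay, a number 13.3 percentage points higher (beyond the scatter) from compound 2 to compound 1 and a number 4.9 percentage points higher (within the scatter) from compound 3 to compound 4, 8.4 percentage points apart, within the scatter of two such steps. Within the data shown here, this shows no conflict between the two cores, but it does not show that the change carries over with the same size, nor that it is lost on the core of compound 3, since only two steps are available and the ring of compound 2 already carries a chloro whereas the ring of compound 3 carries none.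

The compounds shown leave open whether a fluoro, methyl or methoxy group in place of hydrogen on the same aromatic carbon would behave as chloro does on either core. They also leave open how the series responds at the other end of the molecule, for instance with a carboxylic acid or an amine replacing the sulfur-bearing end group, or with a longer chain leading to it.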